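The source may hold more compounds than are shown below. What is called first, only, known or untested is meant among the compounds shown, and "the series" means these compounds.

Compound 1 `Cc1ccccc1Cc1ccc(N2CCC[C@H]2CC(=O)O)cc1` carries a five-membered saturated ring with a carboxymethyl group. In an assay on HEK293 cells for binding affinity to Free fatty acid receptor 1 (Homo sapiens), read by scintillation counting and radioligand binding, with a stated time of 1 h (on this read-out lower numbers stand for stronger inhibition and higher numbers for weaker inhibition), compound 1 gives 1300 nM. Its companion compound 3 `Cc1ccccc1Cc1ccc(N2CC[C@H](C)[C@H]2CC(=O)O)cc1` adds a methyl to a saturated ring carbon and gives 310 nM, so a 4.2-fold lower number from compound 1 to compound 3 (0.62 log units; beyond the scatter). Compound 2 `O=C(O)C[C@@H]1CCCN1c1ccc(Oc2cccc(Cl)c2)cc1` is reported as "not determined" (no result reported). Among the two numbers in hand, compound 1 therefore stands highest.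

Compound 4 `Cc1ccccc1Cc1ccc(N2C[C@@H](C(F)(F)F)C[C@H]2CC(=O)O)cc1` differs from compound 1 by trifluoromethyl in place of hydrogen on a saturated ring carbon. Going by the values given here, the only step that speaks to a group entering a saturated ring carbon of this core is a 4.2-fold lower number from compound 1 to compound 3 (0.62 log units; beyond the scatter), a modest gain, though there the group was methyl on another ring carbon. A similar but smaller move is expected. Compound 4 is estimated at 650 nM, between 200 nM and 2000 nM. That estimate means a 2.0-fold lower number from compound 1 to compound 4 (0.30 log units; within the scatter).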

Compound 4, inhibition constant: 73 nM
Compound 4: middle estimate off by 8.9-fold (0.95 log units), on the high side, outside the stated range (below it).
By their numbers in this assay, from the lowest: compound 4; then compound 3; then compound 1.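

Trifluoromethyl in place of hydrogen on this saturated ring carbon, two ring bonds from the ring nitrogen, gives an 18-fold lower number from compound 1 to compound 4 (1.25 log units; beyond the scatter). This is a large step, whereas the methyl step on another ring carbon was modest, so the core of compound 1 accepts a group of four heavy atoms here and its number falls sharply. No measurement offered here accounts for the size of this step.

From the compounds shown here alone, how a methyl group, a single fluorine atom or a hydroxyl group would fare on this same ring carbon stays open. So does whether trifluoromethyl itself matters here, or simply any group at this place.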